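This account rests on a few compounds, and the source may have more. Where it says the series, first, only, none or still open, it means among the compounds named here.

Compound 1 `CCn1cc(-c2nc3ccccc3[nH]2)c(=O)c2cc(F)c(N3CCNCC3)cc21` and compound 2 `CCn1cc(-c2nc3ccccc3[nH]2)c(=O)c2cc(F)c(N3CCNCC3)nc21` share most of their structure, but the difference between the two cores is not broken down here. In a functional assay on THP-1 cells (Homo sapiens) for cytotoxicity, read by sulforhodamine B assay, with a stated time of 48 h (on this read-out higher numbers stand for weaker inhibition and lower numbers for stronger inhibition), compound 1 gives only a limit of the assay, > 10000 nM. Compound 2 likewise reaches only a limit in this assay, > 10000 nM. Compound 3 `CCn1cc(-c2nc3ccc(N)cc3[nH]2)c(=O)c2cc(F)c(N3CCNCC3)cc21` arises from compound 1 by amino in place of hydrogen on an aromatic carbon, and in this assay compound 3 gives 10000 nM. The step of a number no higher from compound 1 to compound 3 (the limit leaves the size open) cannot be sized because the limit of > 10000 nM in this assay, at which 2 of the 3 values shown sit, hides where compound 1 truly lies. Compound 4 `CCn1cc(-c2nc3ccc(N)cc3[nH]2)c(=O)c2cc(F)c(N3CCNCC3)nc21` arises from compound 2 by the same change, (amino in place of hydrogen on an aromatic carbon), at the same place in the ring system. Among the measured compounds shown here, the only guidance is this one earlier step, so the change from compound 2 to compound 4 is expected to be similarly small, a step that the limit leaves unreadable from compound 2 to compound 4, because a number no higher from compound 1 to compound 3 (the limit leaves the size open) gave no visible gain. Compound 4 is therefore estimated to sit in this assay at about 15000 nM, most likely between 8000 nM and 40000 nM, and quite possibly again only as a limit.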

Compound 4, half-maximal inhibitory concentration: 8200 nM
Beside the measured number, compound 4's estimate is 1.8-fold (0.26 log units) above it; low and high end bracket the measured number.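

Replacing hydrogen with amino on an aromatic carbon of the second core gives an at least 1.2-fold lower number from compound 2 to compound 4 (0.08 log units; that floor lies within the scatter) in this assay. On both cores, the compound carrying the amino group gives an actual number, while the compound without it stops at a limit of the assay, so the change points the same way in these two pairs, although the floor of the new step offers no firm evidence of a real gain. What this does not show is that the size of the change carries from one core to the other, since neither step can be read in full and the two cannot be compared: the same change on two cores in this assay, a number no higher (the limit leaves the size open) from compound 1 to compound 3 and an at least 1.2-fold lower number (0.08 log units; that floor lies within the scatter) from compound 2 to compound 4; the limit leaves it open whether they differ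

The compounds shown leave open whether another group at this place on the ring, such as a hydroxyl, a methoxy or a carboxylic acid, would give a clearly lower number on either core. They also leave open how the amino group would behave on a core whose parent compound gives a number rather than a limit.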